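Demethylation step carried from one core to another

The compounds below may be only part of what the source reports. "The series", "measured", "known", "first", "only" and "open" are said of these compounds alone.

Compound 1 `COc1ccc(C(=O)NNC(=S)Nc2csc(-c3ccc(C)cc3)c2)cc1` and compound 2 `Cc1ccc(-c2cc(NC(=S)NNC(=O)c3ccc(O)cc3)cs2)cc1` share one core; compound 3 `COc1ccc(-c2nnc(Nc3csc(-c4ccccc4)c3)s2)cc1` and compound 4 `Oc1ccc(-c2nnc(Nc3csc(-c4ccccc4)c3)s2)cc1` share another. The difference between the two cores is not broken down here. In a functional assay on MCF7 cells (Homo sapiens) for inhibition, read by colorimetric assay and MTT assay, with a stated time of 72 h (on this read-out lower numbers stand for stronger inhibition and higher numbers for weaker inhibition), compound 1 gives 5000 nM, compound 2 gives 42000 nM and compound 3 gives 60000 nM; compound 4 is not yet measured.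

From compound 1 to compound 2 the change is hydrogen in place of methyl on an oxygen on an aromatic ring. It produced an 8.4-fold higher number from compound 1 to compound 2 (0.92 log units; beyond the scatter). From compound 3 to compound 4 the change is hydrogen in place of methyl on an oxygen on an aromatic ring, the same change at the same place description, on an oxygen on an aromatic ring whose other neighbours are aromatic carbon. Compound 3 holds the highest number of the three measured; against compound 2 it lies within the scatter, against compound 1 beyond it.

Within the data shown here, the step from compound 3 to compound 4 is expected to be a 3.3-fold higher number from compound 3 to compound 4 (0.52 log units; beyond the scatter), resting on the single precedent an 8.4-fold higher number from compound 1 to compound 2 (0.92 log units; beyond the scatter) on the other core, with no second example to confirm it. Compound 4 is estimated at 200000 nM in this assay, between 50000 nM and 800000 nM, and since compound 3 already sits high, a limit rather than a number is a real possibility.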

Compound 4, half-maximal inhibitory concentration: 24000 nM
Compound 4: middle estimate off by 8.3-fold (0.92 log units), on the high side, outside the stated range (below it).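

In this assay, methoxy to hydroxy on the second core gives a 2.5-fold lower number from compound 3 to compound 4 (0.40 log units; beyond the scatter), so the loss seen on the first core does not recur. Set side by side, the two steps run in opposite directions and do not agree: the same change on two cores in this assay, an 8.4-fold higher number (0.92 log units; beyond the scatter) from compound 1 to compound 2 and a 2.5-fold lower number (0.40 log units; beyond the scatter) from compound 3 to compound 4, 21-fold (1.32 log units) apart, beyond the scatter of two such steps

Among these compounds, this shows that, in this series, the step measured on the core of compound 1 could not be carried over to the core of compound 3, in either direction or size; it does not show what sets the two cores apart, and with only one pair on each core, it gives no rule for a further core.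

Still open, from the compounds shown here alone, is whether an amine or an ethoxy group in place of the methoxy would follow the step on one core, on the other, or on neither. Also open, going by these compounds, is which part of the difference between the two cores decides the direction of the step.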